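A few compounds are considered here, and "the series" means these few. Any claim that something is new, unique, unknown or untested is made for them only; others in the source may bear on it.

Compound 2 `COc1cc(Cl)cc(-c2nn(-c3cccc(NC(=O)Nc4ccc(Cl)c(Cl)c4)c3)cc2-c2ccncc2)c1` and compound 1 `COc1cc(Cl)cc(-c2nn(-c3cccc(NC(=O)Nc4ccc(Cl)c(C(F)(F)F)c4)c3)cc2-c2ccncc2)c1` share the same core and differ only in the group carried on the amide-type nitrogen. In a functional assay on MDA-MB-435 cells (Homo sapiens) for inhibition, read by sulforhodamine B assay, with a stated time of 48 h, tested at 1 uM (on this read-out higher numbers stand for a weaker effect at the one concentration tested and lower numbers for a stronger effect), compound 2 gives 85%, and compound 1 gives 81%. Compound 2 thus has the larger of the two numbers seen so far, but the measured step between these two values is a number 4 percentage points higher from compound 1 to compound 2 (within the scatter), which leaves the two within the scatter of each other, so neither can be ranked above the other.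

Compound 3 `COc1cc(Cl)cc(-c2nn(-c3cccc(NC(=O)Nc4cccc(C(F)(F)F)c4)c3)cc2-c2ccncc2)c1` has not yet been measured. It differs from compound 2 by 3-(trifluoromethyl)phenyl in place of 3,4-dichlorophenyl on an amide-type nitrogen. Going by the values given here, the only measured step that bears on this change is a number 4 percentage points higher from compound 1 to compound 2 (within the scatter), in which chloro in place of trifluoromethyl on an aromatic carbon moved the number by no more than the scatter. Among the compounds with values here, the change to compound 3 goes further, exchanging the whole 3,4-dichlorophenyl for 3-(trifluoromethyl)phenyl, and no measured pair covers that part on its own.

On this basis no step beyond the scatter is expected, with the estimated step being a number 3 percentage points lower from compound 2 to compound 3 (within the scatter). Compound 3 is therefore estimated at 82%, within a range from 68% to 95%.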

Compound 3, a percentage reported as activity, at one concentration (the size of the read-out at that concentration, not a potency): 85%
For compound 3 the middle estimate is 3 percentage points below the measured one; the range from low to high includes it.
By their numbers in this assay, from the lowest: compounds 1, 2 and 3 (each within the scatter of the next).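

In this assay, the full exchange of the aryl group on the amide-type nitrogen, which the earlier pair did not cover, gives no change at the digits printed from compound 2 to compound 3 (within the scatter) and so stays within the scatter even though both substituents on the ring differ. The second new pair, with hydrogen in place of chloro on an aromatic carbon, gives a number 4 percentage points higher from compound 1 to compound 3 (within the scatter) and shows that compound 3, without the chloro of compound 1, also cannot be told apart from it at the one concentration tested. The three aryl groups on this nitrogen therefore cannot be ranked against one another, and no supporting evidence bears on why these numbers lie so close together.

The compounds shown carry only chloro, trifluoromethyl and hydrogen on this aryl ring, so it remains open whether a methoxy group, a nitrile or an amine there, or a longer alkyl chain in place of the whole ring, would move the number beyond the scatter. The rest of the shared core is identical in all three compounds, which leaves open what a change elsewhere in it would do.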